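Removing the Bromobenzyl Ether From Compound 3

This account rests on a few compounds, and the source may have more. Where it says the series, first, only, none or still open, it means among the compounds named here.

Compound 3 `O=C1NC(=S)S/C1=C\C=C\c1ccccc1OCc1ccccc1Br` stands highest of the three measured compounds in a functional assay on DLD-1 cells (Homo sapiens), read by microscopy and crystal violet staining, with a stated time of 20 h, tested at 10 ug/mL (a lower number here means less inhibition, a higher number more inhibition at the concentration tested (going by the name of the read-out)), where compound 3 gives 78%. Compound 1 `COc1ccccc1/C=C/C=C1\SC(=S)NC1=O` gives 69% and compound 2 `O=C1NC(=S)S/C1=C\C=C\c1ccccc1OCc1ccccc1` gives 65%. The step of a number 13 percentage points higher from compound 2 to compound 3 (beyond the scatter) lies beyond the scatter, whereas a number 9 percentage points higher from compound 1 to compound 3 (within the scatter) and a number 4 percentage points lower from compound 1 to compound 2 (within the scatter) lie within it. Compound 4 `O=C1NC(=S)S/C1=C\C=C\c1ccccc1O` differs from compound 3 in one place: hydrogen in place of 2-bromobenzyl on an oxygen on an aromatic ring. For the measured compounds named here, no measured step removes the whole group from the oxygen; the nearest comparisons are the two steps leading to compound 3, and the larger of them was only modest. A modest loss is therefore expected, a number 18 percentage points lower from compound 3 to compound 4 (beyond the scatter), though it may well fall within the scatter. For compound 4 the estimated value is 60%, within 40% to 78%.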

Compound 4, a percentage reported as inhibition, at one concentration (the size of the read-out at that concentration, not a potency): 65%
Compound 4: middle estimate off by 5 percentage points, on the low side; the range from low to high includes it.
By their numbers in this assay, from the lowest: compounds 2, 4, 1 and 3 (each within the scatter of the next, the first and the last beyond it).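

In this assay, hydrogen on the oxygen on an aromatic ring separates from only one of the three ether groups: 2-bromobenzyl (a number 13 percentage points lower from compound 3 to compound 4 (beyond the scatter)), but neither benzyl (no change at the digits printed from compound 2 to compound 4 (within the scatter)) nor methyl (a number 4 percentage points lower from compound 1 to compound 4 (within the scatter)). An ether on this oxygen is therefore not required to reach this level of inhibition, and the step depends on which group is removed. Nothing available explains this difference. Still open, going by these compounds, is whether an amine or a carboxylic acid at the end of a longer chain on this oxygen would change the number. On these data alone, whether these steps would hold at other concentrations also remains open.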